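Replacing the benzyl substituent: from compound 2 to compound 4

The source may hold more compounds than are shown below. What is called first, only, known or untested is meant among the compounds shown, and "the series" means these compounds.

Measured compounds in a functional assay on B16 cells (Mus musculus) for antiproliferative activity, read by MTT assay, with a stated time of 24 h; on this read-out lower numbers stand for stronger inhibition and higher numbers for weaker inhibition:
compound 1 `COc1cc(OC)c(-c2coc3cc(OCC=C(C)C)ccc3c2=O)cc1OC` gives 1090 nM
compound 2 `COc1cc(OC)c(-c2coc3cc(OCc4ccccc4C)ccc3c2=O)cc1OC` gives 2150 nM
compound 3 `COc1cc(OC)c(-c2coc3cc(OCc4ccccc4C(F)(F)F)ccc3c2=O)cc1OC` gives 8550 nM

Compound 2 holds the second highest number of the three. Its nearest neighbour is compound 1, where the step of a 2.0-fold higher number from compound 1 to compound 2 (0.30 log units; within the scatter) stays within the scatter, so no order between these two can be read. Compound 3 lies furthest away, with a 4.0-fold higher number from compound 2 to compound 3 (0.60 log units; beyond the scatter), a modest weakening beyond the scatter. The other route, a 7.8-fold higher number from compound 1 to compound 3 (0.89 log units; beyond the scatter), is likewise modest and beyond the scatter.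

Compound 4 `COc1cc(OC)c(-c2coc3cc(OCc4cccc(Br)c4)ccc3c2=O)cc1OC` is not yet measured. It differs from compound 2 in one place: 3-bromophenyl in place of 2-methylphenyl on a saturated chain carbon bound to an oxygen on an aromatic ring. Among the measured compounds shown here, no measured pair shows this exact exchange. The step from compound 2 to compound 3 shows that changing the group on the aromatic carbon of the benzyl ring can move the number modestly, whereas the step from compound 1 to compound 2 shows that swapping the whole group on the saturated chain carbon can leave it within the scatter. Taken together, a step of no more than modest size is expected, and its direction is not decided by the data.

Compound 4 is therefore estimated at 2500 nM, within a range from 800 nM to 8000 nM. This estimate means a step of a 1.2-fold higher number from compound 2 to compound 4 (0.07 log units; within the scatter), expected to stay close to the scatter.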

Compound 4, half-maximal inhibitory concentration: 4400 nM
Compound 4: the middle estimate sits 1.8-fold (0.25 log units) below what was measured; the range from low to high includes it.
By their numbers in this assay, from the lowest: compounds 1 and 2 (each within the scatter of the next); then compounds 4 and 3 (each within the scatter of the next).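

In this assay the exchange of 2-methylphenyl for 3-bromophenyl on the saturated chain carbon bound to an oxygen on an aromatic ring gives a 2.0-fold higher number from compound 2 to compound 4 (0.31 log units; beyond the scatter) and so adds a second benzyl change that moves the number modestly beyond the scatter, this time with the whole substituted ring swapped rather than only the group on it. The step of a 1.9-fold lower number from compound 3 to compound 4 (0.29 log units; within the scatter) stays within the scatter, so no order can be read between the 3-bromophenyl and 2-(trifluoromethyl)phenyl groups, while a 4.0-fold higher number from compound 1 to compound 4 (0.61 log units; beyond the scatter) places compound 4 beyond the scatter from the 2-methylprop-1-en-1-yl group, and compound 2 goes against any general separation of the benzyl compounds from compound 1 because its step to compound 1 stays within the scatter. No measurement presented here accounts for the shift caused by the exchange.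

The compounds shown leave open whether the bromine itself or its place on the ring carries the step, a question that 2-bromophenyl or 3-methylphenyl would address. Also open, from the compounds shown here alone, is how an unsubstituted benzyl group, or a benzyl ring bearing an amine or a carboxylic acid, would read in this assay.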